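Ester in place of vinyl at the sulfur-bound chain carbon

A few compounds are considered here, and "the series" means these few. Any claim that something is new, unique, unknown or untested is made for them only; others in the source may bear on it.

The series shares the core of compound 1 `C#CCSc1nnc(C)n1N1C(=O)c2ccccc2C1=O`, varying only in the group attached through the sulfur. In a functional assay on PC-3M cells (Homo sapiens) for cytotoxicity, read by MTT assay, with a stated time of 48 h (a lower number here means a stronger inhibitor, a higher number a weaker inhibitor), compound 1 gives > 200000 nM, which is a limit of the assay and not a number. Compound 2 `Cc1nnc(SCc2ccccc2Cl)n1N1C(=O)c2ccccc2C1=O` carries a 2-chlorophenyl in place of ethynyl on a saturated chain carbon bound to a sulfur; in this assay compound 2 gives > 200000 nM, again a limit. The step that the two limits leave unreadable from compound 1 to compound 2 cannot be read. Compound 3 `C=CCSc1nnc(CC)n1N1C(=O)c2ccccc2C1=O` in this assay gives > 200000 nM, also a limit, so compound 3 stands exactly where the other two stand, at the limit of > 200000 nM in this assay, at which 3 of the 3 values shown sit.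

Compound 4 `CCOC(=O)CSc1nnc(CC)n1N1C(=O)c2ccccc2C1=O` differs from compound 3 by ethoxycarbonyl in place of vinyl on a saturated chain carbon bound to a sulfur. Among the compounds with values here, no measured step reads as a number: the single step between measured compounds is unreadable, and every value shown is a limit. There is thus no basis for expecting a step of any size or direction beyond the scatter, and the most probable outcome is that compound 4 also returns a limit rather than a number. The estimate for compound 4 in this assay is 300000 nM, with an expected range from 100000 nM to 1000000 nM. The step expected on this basis is a step that the limit leaves unreadable from compound 3 to compound 4.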

Compound 4, half-maximal inhibitory concentration: > 200000 nM
Compound 4 gave a limit, no number (the forecaster's own chance of this, stated with the estimate: 85%); the middle value is on the limit's open side.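

In this assay compound 4 gives > 200000 nM, a limit and not a number. The step between compound 3 and compound 4 therefore cannot be read, and the series offers no readable step: the limit of > 200000 nM in this assay, at which 4 of the 4 values shown sit.

The compounds shown leave open whether any group attached through the sulfur gives a measurable value in this assay.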